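The source may report more compounds than this note shows. Statements on the series, on what has been measured and on what is new or still open speak of the compounds shown alone.

Compound 1 `C#CCN(C)CCCCOc1ccc2c(c1)CCCC2=O`: 30.9%
Compound 2 `C#CCN(C)CCCCCOc1ccc2c(c1)CCCC2=O`: 26.1%

In an ADME assay on BTI cells for inhibition of Amine oxidase [flavin-containing] A (Homo sapiens), read by fluorescence and Amplex Red, with a stated time of 15 min, tested at 100 uM (a higher number here means more inhibition at the concentration tested (going by the name of the read-out), a lower number less inhibition), compound 1 gives 30.9%, and compound 2 gives 26.1%. Going by the values given here, the only measured step, a number 4.8 percentage points lower from compound 1 to compound 2 (within the scatter), lies within the scatter, so compound 2 stands within the scatter of the other number. Compound 3 `C#CCN(C)CCCCCCOc1ccc2c(c1)CCCC2=O` differs from compound 2 by (methyl(propargyl)amino)methyl in place of methyl(propargyl)amino on a saturated chain carbon, five bonds along the chain from an oxygen on an aromatic ring. The step that bears on this is a number 4.8 percentage points lower from compound 1 to compound 2 (within the scatter), the same change one bond nearer the oxygen, and as it was within the scatter no change beyond the scatter is expected in this assay. Compound 3 is therefore estimated at 23%, range 10% to 38%, an expected step of a number 3.1 percentage points lower from compound 2 to compound 3 (within the scatter).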

Compound 3, a percentage reported as inhibition, at one concentration (the size of the read-out at that concentration, not a potency): 25%
Beside the measured number, compound 3's estimate is 2 percentage points below it, and the stated range covers the measured number.
By their numbers in this assay, from the lowest: compounds 3, 2 and 1 (each within the scatter of the next).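

In this assay the change on this saturated chain carbon, five bonds along the chain from an oxygen on an aromatic ring, gives a number 1.1 percentage points lower from compound 2 to compound 3 (within the scatter) and so repeats the earlier result one bond further out. The larger replacement, 2-(methyl(propargyl)amino)ethyl in place of methyl(propargyl)amino, gives a number 5.9 percentage points lower from compound 1 to compound 3 (within the scatter) and so also stays within the scatter, leaving chain length unresolved across compounds 1, 2 and 3 in this assay. No measured evidence bears on this result.

Still open, from the compounds shown here alone, is whether a shorter chain, or a benzyl group in place of propargyl on the amine, would separate from these compounds beyond the scatter.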